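The source may hold more compounds than are shown below. What is called first, only, known or untested is meant among the compounds shown, and "the series" means these compounds.

Compound 1 `N#CCCn1nc(-c2ccc(OCc3cccc(Cl)c3)cc2)oc1=S` and compound 2 `N#CCCn1nc(-c2ccc(OCc3ccc(Cl)cc3)cc2)oc1=S` share one core, while compound 3 `N#CCCN1N=C(c2ccc(OCc3cccc(Cl)c3)cc2)OCC1=O` and compound 4 `N#CCCN1N=C(c2ccc(OCc3ccc(Cl)cc3)cc2)OCC1=O` share another; how the core of compound 3 differs from that of compound 1 is not broken down here. In an assay for inhibition of Amine oxidase [flavin-containing] A (Rattus norvegicus) (on this read-out higher numbers stand for weaker inhibition and lower numbers for stronger inhibition), compound 1 gives 11000 nM and compound 2 gives 2700 nM. The change between them, (4-chlorophenyl in place of 3-chlorophenyl on a saturated chain carbon bound to an oxygen on an aromatic ring), produced a 4.1-fold lower number from compound 1 to compound 2 (0.61 log units; beyond the scatter). In this assay compound 3 gives 13000 nM, close to the number for compound 1. Compound 4 carries the same change, (4-chlorophenyl in place of 3-chlorophenyl on a saturated chain carbon bound to an oxygen on an aromatic ring), on the core of compound 3. Going by the values given here, the expectation for compound 4 rests on the single measured example of this change, a 4.1-fold lower number from compound 1 to compound 2 (0.61 log units; beyond the scatter), with some allowance for a smaller effect on a different core. Compound 4 is therefore expected to show a 3.7-fold lower number from compound 3 to compound 4 (0.57 log units; beyond the scatter) in this assay. Compound 4 is estimated at 3500 nM, with a likely range from 1500 nM to 9000 nM.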

Compound 4, half-maximal inhibitory concentration: 3400 nM
Estimate against measurement, compound 4: 1.0-fold (0.01 log units) above, and the stated range covers the measured number.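

The change from 3-chlorophenyl to 4-chlorophenyl gave a 3.8-fold lower number from compound 3 to compound 4 (0.58 log units; beyond the scatter) in this assay, so it lowered the number on the second core as it had on the first. The size of the step carried over between the two cores: the same change on two cores in this assay, a 4.1-fold lower number (0.61 log units; beyond the scatter) from compound 1 to compound 2 and a 3.8-fold lower number (0.58 log units; beyond the scatter) from compound 3 to compound 4, 1.1-fold (0.03 log units) apart, within the scatter of two such steps. This rests on just two pairs, so it shows that the change transferred between these two cores, but not that it would do so on any other core, nor why the 4-chlorophenyl compounds give the lower numbers.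

The compounds shown leave open whether bromine or fluorine in place of the chlorine, or an unsubstituted phenyl, would follow the same course. They also leave open whether the step would survive replacing the nitrile chain with a longer chain or an amine.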